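The compounds below may be only part of what the source reports. "The series", "measured", "known", "first", "only" and "open" are said of these compounds alone.

Series notes. Compound 1 `C=C1C[C@]23C[C@@]1(O)CC[C@H]2[C@@]12C=CC(=O)[C@@](C)(C(=O)O1)[C@H]2[C@@H]3C(=O)OC`, compound 2 `C=C1C[C@]23C[C@@]1(O)CC[C@H]2[C@@]12C=C[C@H](O)[C@@](C)(C(=O)O1)[C@H]2[C@@H]3C(=O)OC` and compound 3 `C=C1[C@@H]2OC(=O)[C@H]3[C@@H]4[C@@]5(C)C(=O)C=C[C@@]4(OC5=O)[C@@H]4CC[C@]1(O)C[C@]234` share one core and have each been run in a functional assay on PSN1 cells (Homo sapiens) for cytotoxicity, read by luminescence and CellTiter-Glo, with a stated time of 24 h; a lower number here means a stronger inhibitor, a higher number a weaker inhibitor. In this assay compound 1 returns only a limit, > 10000 nM. In this assay compound 2 also returns only a limit, > 10000 nM. In this assay compound 3 again returns only a limit, > 10000 nM. Among the compounds with values here, compound 2 thus stands at the edge of what was measured, with no number of its own and no measured step between it and any other compound; all three results sit at the same point, (the limit of > 10000 nM in this assay, at which 3 of the 3 values shown sit). The next compound, compound 4 `C=C1[C@@H](O)[C@]23C[C@@]1(O)CC[C@H]2[C@@]12C=C[C@H](O)[C@@](C)(C(=O)O1)[C@H]2[C@@H]3C(=O)OC`, has not yet been measured in this assay. Its difference from compound 2 is hydroxy in place of hydrogen on a saturated ring carbon. Within the data shown here, no measured pair reports a number, so no step size can be read off the data. With every result at the limit, the expected step is a step that the limit leaves unreadable from compound 2 to compound 4, none beyond the scatter. Compound 4 is accordingly expected to come in at 15000 nM, within 5000 nM to 50000 nM, and most probably once more as a limit rather than a number.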

Compound 4, half-maximal inhibitory concentration: > 10000 nM
Compound 4: a limit, no number; the forecaster's own chance of this, stated with the estimate: 85%; the middle value is on the limit's open side.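

In this assay compound 4 returns only a limit, > 10000 nM. Within the data shown here, compound 2 also sits at a limit, so no step between compound 2 and compound 4 can be read for hydroxy in place of hydrogen on a saturated ring carbon: the limit of > 10000 nM in this assay, at which 4 of the 4 values shown sit. The compounds shown leave open whether that hydroxy changes cytotoxicity at all, and none of them gives a number for comparison.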